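The source may report more compounds than this note shows. Statements on the series, on what has been measured and on what is new or still open speak of the compounds shown alone.

Going by the values given here, of the three compounds measured so far in a physicochemical assay for permeability, using PAMPA, at pH 7.4 (on this read-out lower numbers stand for lower permeability and higher numbers for higher permeability), compound 2 `Cc1ccccc1S(=O)(=O)NC(=O)c1ccc(Nc2nc(NC3(c4ccc(Cl)cc4)CC3)nc(OCC(F)(F)F)n2)cc1` stands highest: in this assay compound 2 gives 265 nm/s. Compound 1 `CC(C)OC(=O)NCCS(=O)(=O)NC(=O)c1ccc(Nc2nc(NC3(c4ccc(Cl)cc4)CC3)nc(OCC(F)(F)F)n2)cc1` gives 71 nm/s in this assay, and compound 3 `CNC(=O)NCCS(=O)(=O)NC(=O)c1ccc(Nc2nc(NC3(c4ccc(Cl)cc4)CC3)nc(OCC(F)(F)F)n2)cc1` gives 40 nm/s. Both steps from compound 2 to the other two lie beyond the scatter: a 3.7-fold higher number from compound 1 to compound 2 (0.57 log units; beyond the scatter) and a 6.6-fold lower number from compound 2 to compound 3 (0.82 log units; beyond the scatter). The step between compound 1 and compound 3 is within the scatter, a 1.8-fold lower number from compound 1 to compound 3 (0.25 log units; within the scatter), so nothing separates those two.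

Compound 4 `CC(=O)NCCS(=O)(=O)NC(=O)c1ccc(Nc2nc(NC3(c4ccc(Cl)cc4)CC3)nc(OCC(F)(F)F)n2)cc1` differs from compound 2 in one place: 2-acetamidoethyl in place of 2-methylphenyl on a sulfonyl sulfur. The measured steps that bear on this are the two at the same sulfonyl sulfur, where 2-methylphenyl was exchanged for a substituted ethyl chain: a 3.7-fold higher number from compound 1 to compound 2 (0.57 log units; beyond the scatter) read in reverse, and a 6.6-fold lower number from compound 2 to compound 3 (0.82 log units; beyond the scatter). Both were modest and both lowered the number. The 2-acetamidoethyl group entering in compound 4 resembles the groups present in compound 1 and compound 3, so a lowering of similar size is expected, with compound 4 landing in the region of those two. In this assay compound 4 is therefore expected to give about 60 nm/s, within a range from 25 nm/s to 140 nm/s. This corresponds to an expected step of a 4.4-fold lower number from compound 2 to compound 4 (0.65 log units; beyond the scatter).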

Compound 4, apparent permeability: 7 nm/s
Beside the measured number, compound 4's estimate is 8.6-fold (0.93 log units) above it; the whole stated range lies above it.
By their numbers in this assay, from the lowest: compound 4; then compounds 3 and 1 (each within the scatter of the next); then compound 2.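

At the sulfonyl sulfur, 2-acetamidoethyl in place of 2-methylphenyl gives in this assay a large step, a 38-fold lower number from compound 2 to compound 4 (1.58 log units; beyond the scatter) and so shows that the substituted ethyl chains at this position do not all stand at one level. The end of the chain decides this: methyl in place of methylamino on the carbonyl carbon gives a 5.7-fold lower number from compound 3 to compound 4 (0.76 log units; beyond the scatter) and methyl in place of isopropoxy gives a 10-fold lower number from compound 1 to compound 4 (1.01 log units; beyond the scatter) while methylamino in place of isopropoxy had given only a 1.8-fold lower number from compound 1 to compound 3 (0.25 log units; within the scatter) and so had not separated compound 1 from compound 3. No measurement shown here gives a reason for the low number of compound 4.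

On these data alone, what a plain ethyl group or a 2-methoxyethyl chain would give on the same sulfonyl sulfur remains open, and with it whether the low number of compound 4 belongs to the acetamide or to the short chain as such. Also open, as far as these compounds go, is whether a propionyl or a benzoyl group in place of the acetyl would stay with compound 4 or move towards compound 1 and compound 3.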